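Removing the methoxycarbonyl group: from compound 2 to compound 3

The compounds below may be only part of what the source reports. "The series", "measured", "known", "first", "only" and "open" are said of these compounds alone.

Measured in an ADME assay on HT-29 cells (Homo sapiens) for cytotoxicity, read by MTT assay, with a stated time of 72 h; on this read-out lower numbers stand for stronger inhibition and higher numbers for weaker inhibition:
Compound 1 `COc1ccc(OC)c(C2=C(c3cc(OC)c(OC)c(OC)c3)C(=O)CC2O[SiH2]C(C)(C)C)c1`: 5 ug/mL
Compound 2 `COC(=O)c1cc(C2=C(c3cc(OC)c(OC)c(OC)c3)C(=O)CC2O[SiH2]C(C)(C)C)ccc1OC`: > 100 ug/mL

Compound 2 stands at > 100 ug/mL, which is a limit of the assay and not a number. Compound 3 `COc1cc(C2=C(c3cc(C)c(OC)c(C)c3)C(O[SiH2]C(C)(C)C)CC2=O)cc(OC)c1OC` has yet to be measured. It carries 4-methoxy-3,5-dimethylphenyl in place of 4-methoxy-3-(methoxycarbonyl)phenyl on a double-bonded ring carbon. Among the compounds with values here, only one measured step bears on this change, at the same place: an at least 20-fold higher number from compound 1 to compound 2 (1.30 log units; beyond the scatter). That step is large and brought in the group that compound 3 lacks. A large step to a lower number is therefore expected in this assay, although the entering group differs from the 2,5-dimethoxyphenyl of compound 1. The expected step is an at least 10-fold lower number from compound 2 to compound 3 (1.00 log units; beyond the scatter). For compound 3 the estimate is 10 ug/mL, with an expected range from 2 ug/mL to 50 ug/mL.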

Compound 3, half-maximal inhibitory concentration: 10 ug/mL
Compound 3: middle estimate and measured number agree at the digits printed; measured number inside the range.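

In this assay, placing 4-methoxy-3,5-dimethylphenyl on the double-bonded ring carbon in place of 4-methoxy-3-(methoxycarbonyl)phenyl gives an at least 10-fold lower number from compound 2 to compound 3 (1.00 log units; beyond the scatter). Compound 2 stands at a limit of the assay and not at a number, so this step has no upper bound: the limit of > 100 ug/mL in this assay, at which 1 of the 3 values shown sits.

The other new comparison gives a 2.0-fold higher number from compound 1 to compound 3 (0.30 log units; within the scatter), so 4-methoxy-3,5-dimethylphenyl and 2,5-dimethoxyphenyl cannot be told apart here, and among the three groups shown at this position only the one in compound 2 stands apart.

The compounds shown leave open whether the weak result of compound 2 belongs to the methoxycarbonyl group alone or would also appear with a carboxylic acid or an amide in its place. They also do not show what the methyl groups of compound 3 contribute compared with a plain 4-methoxyphenyl group.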